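Swapping One Fused Ring for Another on the Benzyl Carbon

The compounds below may be only part of what the source reports. "The series", "measured", "known", "first", "only" and "open" are said of these compounds alone.

In a physicochemical assay for lipophilicity, at pH 7.4 (a higher number here means a more lipophilic compound, a lower number a more polar compound), compound 1 `CNC(=O)c1cc(C(=O)NC2CCC2)cn(Cc2ccccc2)c1=O` gives 3.8. Compound 2 `CNC(=O)c1cc(C(=O)NC2CC2)cn(Cc2ccc3nc[nH]c3c2)c1=O` gives 1.2, the lower of the two numbers, and its gap to compound 1 lies beyond the scatter. Compound 3 `CNC(=O)c1cc(C(=O)NC2CC2)cn(Cc2nccc3[nH]ccc23)c1=O` has not yet been measured; it differs from compound 2 by a group of 9 heavy atoms (7 carbon, 2 nitrogen; one five-membered aromatic ring with 1 hetero atom, one six-membered aromatic ring with 1 hetero atom) in place of a group of 9 heavy atoms (7 carbon, 2 nitrogen; one five-membered aromatic ring with 2 hetero atoms, one six-membered aromatic ring of carbon only), on a saturated chain carbon bound to an aromatic nitrogen. Each of the two groups carries 1 hydrogen-bond donor and 1 hydrogen-bond acceptor. Going by the values given here, no measured step of this kind is available, so the expected change from compound 2 to compound 3 is small, a number 0.20 log units higher from compound 2 to compound 3 (within the scatter), within the scatter. Compound 3 is estimated at 1.4, with a range from 0.8 to 2.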

Compound 3, distribution coefficient: 1.7
The estimate for compound 3 lay 0.30 log units below the measured number; measured number inside the range.
By their numbers in this assay, from the lowest: compound 2; then compound 3; then compound 1.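

Two groups with the same atoms and the same counts of donors and acceptors do not give the same number in this assay: the change is a number 0.50 log units higher from compound 2 to compound 3 (beyond the scatter). At this saturated chain carbon bound to an aromatic nitrogen, then, how the atoms are joined matters as well as which atoms are present. Nothing measured here explains the difference.

On these data alone, it remains open whether the same swap gives a similar step in other compounds. Also open, as far as these compounds go, is how a carboxylic acid or an amine in place of these fused rings would read in this assay.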